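Amide and pyridyl replacements on the shared core

The source may report more compounds than this note shows. Statements on the series, on what has been measured and on what is new or still open speak of the compounds shown alone.

Measured so far in an assay on isolated protein for inhibition of alkaline phosphatase, tissue-nonspecific isozyme (Homo sapiens); on this read-out lower numbers stand for stronger inhibition and higher numbers for weaker inhibition:
compound 1, `CNC(=O)c1cncc(NS(=O)(=O)c2cc(Cl)ccc2OC)c1`: 109 nM
compound 2, `COc1ccc(Cl)cc1S(=O)(=O)Nc1cncc(C(=O)Nc2ccccc2)c1`: 310 nM
compound 3, `COc1ccc(Cl)cc1S(=O)(=O)Nc1cncc(-c2ccncc2)c1`: 73 nM

Compound 3 gives the lowest number of the three; against compound 1 the gap is a 1.5-fold lower number from compound 1 to compound 3 (0.17 log units; within the scatter), which does not separate the two, while against compound 2 the gap is a 4.2-fold lower number from compound 2 to compound 3 (0.63 log units; beyond the scatter). The new compound 4, `COc1ccc(Cl)cc1S(=O)(=O)Nc1cncc(C(N)=O)c1`, differs from compound 3 in one place: carbamoyl in place of pyridin-4-yl on an aromatic carbon. Among the measured compounds shown here, two measured steps bear on this. Going from the methylcarbamoyl compound to the pyridin-4-yl compound gave a 1.5-fold lower number from compound 1 to compound 3 (0.17 log units; within the scatter); going from the phenylcarbamoyl compound gave a 4.2-fold lower number from compound 2 to compound 3 (0.63 log units; beyond the scatter). The smaller carbamoyl group therefore seems closest to the case of compound 1, and the reverse direction of a 1.5-fold lower number from compound 1 to compound 3 (0.17 log units; within the scatter) is the best guide. In this assay compound 4 is expected to land near compound 1, with a step of about a 1.5-fold higher number from compound 3 to compound 4 (0.18 log units; within the scatter), not clearly beyond the scatter. The estimate for compound 4 is 110 nM, range 50 nM to 250 nM.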

Compound 4, half-maximal inhibitory concentration: 16 nM
Beside the measured number, compound 4's estimate is 6.9-fold (0.84 log units) above it; measured number below the stated range.
By their numbers in this assay, from the lowest: compound 4; then compounds 3 and 1 (each within the scatter of the next); then compound 2.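

In this assay, the group on the amide nitrogen now shows a clear effect at this position: hydrogen in place of methyl gives a 6.8-fold lower number from compound 1 to compound 4 (0.83 log units; beyond the scatter), and hydrogen in place of phenyl gives a 19-fold lower number from compound 2 to compound 4 (1.29 log units; beyond the scatter), so the three amides order as hydrogen, methyl, phenyl from the lowest number, with none going against that order. Pyridin-4-yl could not be separated from methylcarbamoyl, but carbamoyl in place of pyridin-4-yl gives a 4.6-fold lower number from compound 3 to compound 4 (0.66 log units; beyond the scatter), so this replacement is not neutral for every amide. Nothing measured here accounts for these differences.

On these data alone, it remains open whether the amide hydrogens themselves matter, which a dimethylcarbamoyl group at this place would address. A carboxylic acid or a nitrile there would show whether anything other than the carbamoyl group reaches a similar number.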